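The compounds below may be only part of what the source reports. "The series", "measured", "known", "first", "only" and "open" are said of these compounds alone.

Compound 1 `COc1cc(NC(=O)Nc2cc(Nc3cccc(C(C)(C)C)c3)ncn2)cc(OC)c1` gives 35.1% in a functional assay on NCI-H1581 cells (Homo sapiens) for inhibition, read by MTT assay, with a stated time of 48 h, tested at 10 uM (on this read-out lower numbers stand for less inhibition and higher numbers for more inhibition at the one concentration tested (going by the name of the read-out)), the lowest of the three numbers measured. Compound 2 `COc1cc(NC(=O)Nc2cc(Nc3ccc(C)c(F)c3)ncn2)cc(OC)c1` gives 38%, and the step of a number 2.9 percentage points higher from compound 1 to compound 2 (within the scatter) lies within the scatter. Compound 3 `COc1cc(NC(=O)Nc2cc(Nc3cc(I)ccc3OC)ncn2)cc(OC)c1` gives 59%; the steps of a number 23.9 percentage points higher from compound 1 to compound 3 (beyond the scatter) and a number 21 percentage points higher from compound 2 to compound 3 (beyond the scatter) lie beyond the scatter. All three of these steps change only the aryl group on the nitrogen on the aromatic ring. Compound 4 `CC(C)(C)c1cccc(Nc2cc(NC(=O)Nc3c(Cl)cccc3Cl)ncn2)c1` differs from compound 1 at another place: 2,6-dichlorophenyl in place of 3,5-dimethoxyphenyl on an amide-type nitrogen. Within the data shown here, no measured step touches the amide-type nitrogen, so none of them bears directly on this change. Compound 4 is therefore expected to give about 35%, between 15% and 60%. The step of a number 0.1 percentage points lower from compound 1 to compound 4 (within the scatter) is expected to stay within the scatter.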

Compound 4, a percentage reported as inhibition, at one concentration (the size of the read-out at that concentration, not a potency): 64.3%
Compound 4: middle estimate off by 29.3 percentage points, on the low side; measured number above the stated range.
By their numbers in this assay, from the lowest: compounds 1 and 2 (each within the scatter of the next); then compounds 3 and 4 (each within the scatter of the next).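

Among these compounds, the amide-type nitrogen proves to be a place that moves the number in this assay: 2,6-dichlorophenyl in place of 3,5-dimethoxyphenyl gives a number 29.2 percentage points higher from compound 1 to compound 4 (beyond the scatter), whereas the earlier steps changed only the aryl group on the nitrogen on the aromatic ring. Changes at either place can therefore raise the number. Nothing at hand explains this rise.

The compounds shown leave open whether 2,6-dichlorophenyl gives a similar step alongside the other aryl groups of compounds 2 and 3. Going by these compounds, how a 2-chlorophenyl or a pyridine ring would read at the amide-type nitrogen also remains open.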